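The source may report more compounds than this note shows. Statements on the series, on what has been measured and on what is new or still open speak of the compounds shown alone.

Of the compounds shown here, three have so far been tested in a functional assay on the whole organism (Tail, strain ICR) with Mus musculus as the target, in the tail flick test, with a stated time of 120 min, at a dose of 25 umol/kg by the oral route; a lower number here means a weaker effect, a higher number a stronger effect of the compound at the dose given. Compound 1 `CC[C@H](C)[C@H](NC(=O)CN(c1ncnc2c1ncn2C1CCCCO1)C1CC1)C(=O)OCc1ccccc1` gives 20.4% in this assay. Compound 2 `O=C(O)CNC(=O)CN(c1nc(Cl)nc2[nH]cnc12)C1CC1` gives 19.8%, a number lying within the usual scatter of that of compound 1, so the two cannot be told apart. Compound 3 `C[C@@H](O)[C@H](NC(=O)CN(c1nc(Cl)nc2[nH]cnc12)C1CC1)C(=O)O` gives 37.6%, the highest of the three and beyond the scatter above compound 1. Compound 1 therefore stands second on these numbers, with only compound 3 clearly above it.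

Compound 4 `C[C@H](NC(=O)CN(c1ncnc2c1ncn2C1CCCCO1)C1CC1)C(=O)OCc1ccccc1` has not yet been measured. It differs from compound 1 in one place: methyl in place of sec-butyl on a saturated chain carbon bound to an amide-type nitrogen and a carbonyl carbon. For the measured compounds named here, the only measured step at that same place is the one from compound 2 to compound 3, a number 17.8 percentage points higher from compound 2 to compound 3 (beyond the scatter), where 1-hydroxyethyl replaced hydrogen on a saturated chain carbon bound to an amide-type nitrogen and a carbonyl carbon, on a core unlike that of compound 1 and compound 4. Going by the values given here, that step adds a group; the present change removes most of one, and no measured step shows what shrinking sec-butyl to methyl does. A step within the scatter, or a modest fall, is therefore expected. Compound 4 is expected to give about 16%, somewhere between 5% and 30%. This amounts to an expected step of a number 4.4 percentage points lower from compound 1 to compound 4 (within the scatter).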

Compound 4, a percentage reported as activity, at one dose (the size of the read-out at that dose, not a potency): 25.3%
Compound 4: middle estimate off by 9.3 percentage points, on the low side, and the stated range covers the measured number.
By their numbers in this assay, from the lowest: compounds 2, 1 and 4 (each within the scatter of the next); then compound 3.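

In this assay, putting methyl in place of sec-butyl on a saturated chain carbon bound to an amide-type nitrogen and a carbonyl carbon gives a number 4.9 percentage points higher from compound 1 to compound 4 (within the scatter), so on the core of compound 1 this position accepts the loss of most of sec-butyl, and of its defined stereocentre, with no change that can be read. For the compounds shown here, the only earlier step at this place, a number 17.8 percentage points higher from compound 2 to compound 3 (beyond the scatter), came from a different core and a different pair of groups, so this is the first reading of the position on the core shared by compound 1 and compound 4. Nothing available explains why the step stays within the scatter, and no measurement of any property of these compounds bears on it.

From the compounds shown here alone, it remains open whether hydrogen or 1-hydroxyethyl at this place would make a readable difference on this core, and what a group of another kind, such as a chain ending in an amine or a phenyl ring, would do here. Each number is also a read-out at a single dose and a single time, so it leaves open how these compounds would compare at other doses or times.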